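The source may hold more compounds than are shown below. What is called first, only, known or untested is meant among the compounds shown, and "the series" means these compounds.

In an in vitro ADME assay on microsomes from liver (Homo sapiens) for metabolic stability, in the presence of a further agent that is not named here (a lower number here means slower removal, a higher number faster removal of the compound), compound 1 (`CC(C)(CO)CNC(=O)c1cc2cc(C#N)ccc2n1Cc1cccc(OC(F)(F)F)c1`) gives 20 mL.min-1.g-1, compound 2 (`CCOc1ccc(OC(F)(F)F)cc1Cn1c(C(=O)NCC(C)(C)CO)cc2cc(C#N)ccc21`) gives 20 mL.min-1.g-1 and compound 3 (`COc1ccc(Cl)cc1Cn1c(C(=O)NCC(C)(C)CO)cc2cc(C#N)ccc21`) gives 10 mL.min-1.g-1. The number for compound 3 lies within the scatter of both others. Compound 4 (`COc1ccc(C)cc1Cn1c(C(=O)NCC(C)(C)CO)cc2cc(C#N)ccc21`) differs from compound 3 by methyl in place of chloro on an aromatic carbon, para to a methoxy group: methyl in place of chloro on an aromatic carbon. Among the compounds with values here, the only measured step, no change at the digits printed from compound 1 to compound 2 (within the scatter), is a different change, ethoxy in place of hydrogen, and it stays within the scatter. Within the data shown here, no measured pair exchanges chloro for methyl, so no shift beyond the scatter is expected in this assay. The estimated step is a 1.3-fold higher number from compound 3 to compound 4 (0.11 log units; within the scatter). For compound 4 the expected value is 13 mL.min-1.g-1, with an estimated range from 6 mL.min-1.g-1 to 28 mL.min-1.g-1.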

Compound 4, intrinsic clearance in microsomes: 23 mL.min-1.g-1
Compound 4: the middle estimate sits 1.8-fold (0.25 log units) below what was measured; low and high end bracket the measured number.
By their numbers in this assay, from the lowest: compounds 3, 1, 2 and 4 (each within the scatter of the next, the first and the last beyond it).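

In this assay, methyl in place of chloro on this aromatic carbon, para to a methoxy group, gives a 2.3-fold higher number from compound 3 to compound 4 (0.36 log units; beyond the scatter), a modest step. Within the data shown here, the only earlier step, no change at the digits printed from compound 1 to compound 2 (within the scatter), was a different change, so this pair is the first to show that the group at this position can shift the number beyond the scatter, with chloro on the lower side. Nothing at hand explains this step. Going by these compounds, whether a fluoro group or an amine here would give a number nearer that of compound 3 or compound 4 remains open. Also open, on these data alone, is whether the step holds with an ethoxy group in place of the methoxy group.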